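The source may report more compounds than this note shows. Statements on the series, on what has been measured and on what is new or still open speak of the compounds shown alone.

Measured so far in a functional assay on HL-60 cells (Homo sapiens) for cytotoxicity, read by luminescence and CellTiter-Glo, with a stated time of 3 days; on this read-out higher numbers stand for weaker inhibition and lower numbers for stronger inhibition:
compound 1 `N#Cc1ccc(NC(=O)c2cc(Br)c(-c3ccccc3)cc2O)cc1` — 700 nM
compound 2 `N#Cc1ccc(NC(=O)c2cc(Br)ccc2O)cc1` — 620 nM

For the measured compounds named here, compound 2 is the only measured point beside compound 1. The step of a 1.1-fold lower number from compound 1 to compound 2 (0.05 log units; within the scatter) sits within the scatter, so the two compounds are indistinguishable in this assay and compound 2 cannot be ranked against compound 1. Going by the values given here, the one measured step, hydrogen in place of phenyl on an aromatic carbon, shows only that this phenyl carries no measurable weight on the read-out.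

Compound 3 `COc1ccc(O)c(C(=O)Nc2ccc(C#N)cc2)c1` is the next point. Its change from compound 2: methoxy in place of bromo on an aromatic carbon. Among the compounds with values here, no measured step touches this position or exchanges a bromo for a methoxy, so the step to compound 3 has no direct precedent; the step from compound 1 to compound 2 concerns a different group and shows only that the shared core can lose a substituent without a shift in number. With no evidence either way, compound 3 is expected to come out somewhat weaker, the step of a 2.4-fold higher number from compound 2 to compound 3 (0.38 log units; beyond the scatter) being a guess rather than a projection. The estimate for compound 3 in this assay is 1500 nM, with a range from 500 nM to 5000 nM.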

Compound 3, half-maximal inhibitory concentration: > 10000 nM
Compound 3 gave a limit, no number (the forecaster's own chance of this, stated with the estimate: 15%); at least 6.6-fold (0.82 log units) between middle value and limit.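

In this assay, for the compounds shown here, methoxy in place of bromo on an aromatic carbon gives an at least 16-fold higher number from compound 2 to compound 3 (1.20 log units; beyond the scatter), the first single exchange to fall beyond the scatter. The earlier step, a 1.1-fold lower number from compound 1 to compound 2 (0.05 log units; within the scatter), lay within the scatter and concerned a different place on the shared core, so it left unknown whether any substituent on the core mattered; this carbon, para to a hydroxy group and meta to a large group, is now shown to be sensitive to the exchange of bromo for methoxy. Compound 3 stands at > 10000 nM, which is a limit of the assay and not a number: the limit of > 10000 nM in this assay, at which 1 of the 3 values shown sits.

With only bromo and methoxy compared on this carbon, the compounds shown leave open whether the weaker inhibition follows from the departure of bromo or from the arrival of methoxy, and a chlorine, a methyl or an amine at the same carbon would bear on that question. Also open, going by these compounds, is whether the phenyl exchange would remain within the scatter with methoxy in place of bromo.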